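Methoxy to Fluoro and Expected Cytotoxicity

This account rests on a few compounds, and the source may have more. Where it says the series, first, only, none or still open, it means among the compounds named here.

In an ADME assay on HepG2 2.2.15 cells (Homo sapiens) for cytotoxicity, read by MTT assay (a lower number here means that less compound is tolerated, a higher number that more compound is tolerated), compound 1, `COc1ccc(/C=C/C(=O)Oc2ccc(C(C)=O)cc2)cc1`, gives > 3270000 nM, which is a limit of the test rather than a number. Compound 2, `CC(=O)c1ccc(OC(=O)/C=C/c2ccc(F)cc2)cc1`, gives > 3310000 nM, again a limit. The change between them is fluoro in place of methoxy on an aromatic carbon, and the step that the two limits leave unreadable from compound 1 to compound 2 cannot be read as a size. The limit of > 3270000 nM in this assay, at which 1 of the 3 values shown sits, marks where compound 1 stands. The limit of > 3310000 nM in this assay, at which 1 of the 3 values shown sits, marks where compound 2 stands. Compound 3, `COc1cccc(/C=C/C(=O)OC[C@H]2O[C@@H](Oc3ccc(C(C)=O)cc3)[C@H](O)[C@@H](O)[C@@H]2O)c1`, gives > 1510000 nM in this assay, also a limit, recorded as the limit of > 1510000 nM in this assay, at which 1 of the 3 values shown sits; the difference between its core and the core of compound 1 is not broken down here. Compound 4, `CC(=O)c1ccc(O[C@@H]2O[C@H](COC(=O)/C=C/c3cccc(F)c3)[C@@H](O)[C@H](O)[C@H]2O)cc1`, has not been measured. It differs from compound 3 by fluoro in place of methoxy on an aromatic carbon, the same kind of change as from compound 1 to compound 2, though the place differs: there the new group sits para to a large group, here meta to a large group. The step from compound 3 to compound 4 is expected to be a step that the limit leaves unreadable from compound 3 to compound 4, resting on compound 3, which gives > 1510000 nM, itself a limit. Compound 4 is expected to give 2000000 nM, between 500000 nM and 6000000 nM, most likely again only a limit.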

Compound 4, half-maximal cytotoxic concentration: 828000 nM
The estimate for compound 4 lay 2.4-fold (0.38 log units) above the measured number; low and high end bracket the measured number.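

In this assay, putting fluoro in place of methoxy on the core of compound 3 gives an at least 1.8-fold lower number from compound 3 to compound 4 (0.26 log units; that floor lies within the scatter), so the change may lower the number on this core, but the floor alone does not establish a shift beyond ordinary repeat variation. On these data alone, the true step could be larger, and its size stays open because compound 3 stands at a limit of the test rather than at a number: the limit of > 1510000 nM in this assay, at which 1 of the 4 values shown sits. The same change on the core of compound 1 has limits on both sides and cannot be read, which leaves no size to compare and does not show whether the change carries from one core to the other.

The compounds shown hold only methoxy and fluoro at this spot, so it remains open how an amine or a carboxylic acid would read on the same aromatic carbon. As far as these compounds go, it also remains open whether a longer chain in place of the ethenyl link would alter the step seen with fluoro.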